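The source may report more compounds than this note shows. Statements on the series, on what has been measured and on what is new or still open speak of the compounds shown alone.

- compound 1 `COc1ccccc1NC(=O)c1n[nH]c2ccccc12`: 16000 nM
- compound 2 `COc1cccc(NC(=O)c2n[nH]c3ccccc23)c1`: 36000 nM

In a functional assay on B16 cells (Mus musculus) for inhibition, with a stated time of 3 days (on this read-out higher numbers stand for weaker inhibition and lower numbers for stronger inhibition), compound 2 gives 36000 nM and compound 1 gives 16000 nM, so compound 2 holds the higher of the two numbers, and the gap between the two lies beyond the scatter on this read-out. Compound 3 `Cc1cccc(NC(=O)c2n[nH]c3ccccc23)c1` differs from compound 2 by methyl in place of methoxy on an aromatic carbon with methyl in place of methoxy on an aromatic carbon. For the measured compounds named here, no measured step shows this change, so the expected step of a 1.2-fold lower number from compound 2 to compound 3 (0.08 log units; within the scatter) in this assay is small and none beyond the scatter is expected. The estimate for compound 3 is 30000 nM with an expected range from 12000 nM to 70000 nM for this measurement.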

Compound 3, half-maximal inhibitory concentration: 15000 nM
The estimate for compound 3 lay 2.0-fold (0.30 log units) above the measured number; the measured number falls inside the stated range.
By their numbers in this assay, from the lowest: compounds 3 and 1 (each within the scatter of the next); then compound 2.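

In this assay, methyl in place of methoxy on this aromatic carbon, meta to a large group, gives a 2.4-fold lower number from compound 2 to compound 3 (0.38 log units; beyond the scatter) and so shows that the number responds to a change at this position. The methoxy, with its oxygen and hydrogen-bond acceptor, is not required for the inhibition seen here. Nothing measured here accounts for the step. Going by these compounds, whether an amine, a hydroxyl or a longer chain at this position would shift the number further remains open. So does whether methyl would give a similar step elsewhere on this ring.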